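Chloro to Methyl on the Sulfonyl-Bound Ring: What to Expect

A few compounds are considered here, and "the series" means these few. Any claim that something is new, unique, unknown or untested is made for them only; others in the source may bear on it.

Measured so far:
Compound 1, `CC(O)(C(=O)Nc1ccc(S(=O)(=O)c2ccc(C#N)cc2)cc1)C(F)(F)F`, reaches in a functional assay (Cavia porcellus) with sulfonylurea receptors; K-ATP channels (Homo sapiens) as the target (a lower number here means a stronger inhibitor, a higher number a weaker inhibitor), only a limit of the assay, > 30000 nM.
Compound 2, `CC(O)(C(=O)Nc1ccc(S(=O)(=O)c2ccccc2Cl)cc1)C(F)(F)F`, gives in this assay 2300 nM.

Among the measured compounds shown here, compound 2 thus holds the only true number in this assay; the other value is a limit, not a number. For the measured compounds named here, the single measured step, an at least 13-fold lower number from compound 1 to compound 2 (1.11 log units; beyond the scatter), is large, and its size rests on (the limit of > 30000 nM in this assay, at which 1 of the 2 values shown sits). Compound 3, `Cc1ccccc1S(=O)(=O)c1ccc(NC(=O)C(C)(O)C(F)(F)F)cc1`, differs from compound 2 in one place: methyl in place of chloro on an aromatic carbon. This exchange keeps the group at the same place on the ring and swaps one heavy atom for another of similar bulk. Going by the values given here, no measured step covers such a swap; the step from compound 1 to compound 2 shows only that the group on the sulfonyl sulfur matters. The expected step is therefore a 1.1-fold higher number from compound 2 to compound 3 (0.04 log units; within the scatter), within the scatter. Compound 3 is expected to give about 2500 nM in this assay, with a range from 800 nM to 8000 nM.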

Compound 3, half-maximal inhibitory concentration: 5100 nM
Compound 3: the middle estimate sits 2.0-fold (0.31 log units) below what was measured; the range from low to high includes it.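

In this assay, chloro and methyl are not interchangeable at this place on the ring, ortho to a large group: the change gives a 2.2-fold higher number from compound 2 to compound 3 (0.35 log units; beyond the scatter). Only one heavy atom differs here, so the read-out responds to a much smaller edit than the exchange of the whole group on the sulfonyl sulfur seen earlier. Compared with 4-cyanophenyl, 2-methylphenyl gives an at least 5.8-fold lower number from compound 1 to compound 3 (0.76 log units; beyond the scatter), and the true size of this step stays unknown because it rests on a limit: the limit of > 30000 nM in this assay, at which 1 of the 3 values shown sits.

On these data alone, whether a fluoro, a methoxy or a plain hydrogen at this place would fall nearer to chloro or to methyl remains open. The compounds shown also leave open how either group would behave at another place on the ring, and they give no reason for the difference between them.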